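The compounds below may be only part of what the source reports. "The series", "measured", "known", "first", "only" and "open" are said of these compounds alone.

The measured compounds:
compound 1, `CC(C)c1ccc(OCC(=O)Nc2ccc(OCC(=O)O)c(F)c2)cc1`, 11.8%
compound 2, `CC(C)(C)c1ccc(OCC(=O)Nc2ccc(OCC(=O)O)c(F)c2)cc1`, 7.65%
compound 3, `O=C(O)COc1ccc(NC(=O)COc2cccc(C(F)(F)F)c2)cc1F`, 11.4%

All three were tested in a functional assay on CHO cells for agonist activity at Free fatty acid receptor 1 (Homo sapiens), read by FLIPR, tested at 100 nM; a higher number here means a stronger effect of the compound at the concentration tested, a lower number a weaker effect. Compound 1 and compound 2 share a core and differ in one place: methyl in place of hydrogen on a saturated chain carbon bound to an aromatic carbon and two saturated chain carbons. This change gave a number 4.2 percentage points lower from compound 1 to compound 2 (within the scatter). Compound 3 rests on a different core from compound 1; the difference between the two cores is not broken down here. Compound 4, `CC(Oc1cccc(C(F)(F)F)c1)C(=O)Nc1ccc(OCC(=O)O)c(F)c1`, has not yet been measured. It differs from compound 3 in one place: methyl in place of hydrogen on a saturated chain carbon bound to a carbonyl carbon and an oxygen on an aromatic ring. Within the data shown here, this is the same kind of change as the one from compound 1 to compound 2, but not the same: there the carbon carrying the new methyl is bound to an aromatic carbon and two saturated chain carbons, here it is bound to a carbonyl carbon and an oxygen on an aromatic ring. Because the earlier step of a number 4.2 percentage points lower from compound 1 to compound 2 (within the scatter) stayed within the scatter, the expected step in this assay is also small: a number 1.4 percentage points lower from compound 3 to compound 4 (within the scatter). Compound 4 is therefore estimated at 10%, with a likely range from 2% to 20%.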

Compound 4, a percentage reported as activity, at one concentration (the size of the read-out at that concentration, not a potency): 12.7%
The estimate for compound 4 lay 2.7 percentage points below the measured number, and the stated range covers the measured number.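

In this assay, putting a methyl in place of hydrogen on the saturated chain carbon bound to a carbonyl carbon and an oxygen on an aromatic ring gave a number 1.3 percentage points higher from compound 3 to compound 4 (within the scatter). Set beside the earlier methyl step, this result does not differ from it: the same change on two cores in this assay, a number 4.2 percentage points lower (within the scatter) from compound 1 to compound 2 and a number 1.3 percentage points higher (within the scatter) from compound 3 to compound 4, 5.5 percentage points apart, within the scatter of two such steps. On these two cores, then, the methyl step stays within the usual scatter, but two pairs read at one concentration cannot show that it would do so on other cores, and they say nothing about potency.

The compounds shown leave open how an ethyl group or a hydroxyl group on that same chain carbon would read out. They also leave open whether a chlorine or a nitrile in place of the trifluoromethyl would alter the methyl step.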